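The compounds below may be only part of what the source reports. "The series", "measured", "known", "first", "only" and "open" are said of these compounds alone.

Of the compounds shown here, three from one series have been tested in a functional assay on cells (Cancer cell lines, Homo sapiens) for cytotoxicity, read by sulforhodamine B assay, with a stated time of 48 h; a lower number here means a stronger inhibitor of growth, a higher number a weaker inhibitor of growth. Compound 1 `NS(=O)(=O)c1ccc(-n2nc(-c3ccc(Cl)cc3)cc2-c2cc(O)ccc2O)cc1` gives 35400 nM. Compound 3 `NS(=O)(=O)c1ccc(-n2nc(-c3ccc(Cl)cc3)cc2C2=CC(=O)C=CC2=O)cc1` gives 50200 nM. Compound 2 `CC(=O)NS(=O)(=O)c1ccc(-n2nc(-c3ccccc3)cc2-c2cc(O)ccc2O)cc1` gives 100000 nM, the highest of the three numbers; the difference between the core of compound 2 and the core of compound 1 is not broken down here, beyond the fact that the two differ in more than one place.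

The step from compound 1 to compound 3 is a single structural change, (a group of 8 heavy atoms (6 carbon, 2 oxygen; one six-membered non-aromatic ring of carbon only) in place of a group of 8 heavy atoms (6 carbon, 2 oxygen; one six-membered aromatic ring of carbon only), on an aromatic carbon), and it made a 1.4-fold higher number from compound 1 to compound 3 (0.15 log units; within the scatter). Compound 4 `CC(=O)NS(=O)(=O)c1ccc(-n2nc(-c3ccccc3)cc2C2=CC(=O)C=CC2=O)cc1` has not yet been measured. It relates to compound 2 by a change of the same kind, (a group of 8 heavy atoms (6 carbon, 2 oxygen; one six-membered non-aromatic ring of carbon only) in place of a group of 8 heavy atoms (6 carbon, 2 oxygen; one six-membered aromatic ring of carbon only), on an aromatic carbon). The surroundings are not identical: in compound 1 the ring atom beside the place bears a 4-sulfamoylphenyl group and the farther ring atom bears a 4-chlorophenyl group, whereas in compound 2 the nearer ring atom bears a large group and the farther one a phenyl group.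

Going by the values given here, because the only measured example of this kind of change, a 1.4-fold higher number from compound 1 to compound 3 (0.15 log units; within the scatter), stayed within the scatter, a similarly small step is expected from compound 2 to compound 4, no change at the digits printed from compound 2 to compound 4 (within the scatter), bearing in mind that compound 2 already sits at a very high number. Compound 4 is therefore estimated at 100000 nM, with a likely range from 50000 nM to 200000 nM.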

Compound 4, concentration for total growth inhibition: 100000 nM
Beside the measured number, compound 4's estimate shows no gap at the digits printed, and the stated range covers the measured number.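

Replacing the 2,5-dihydroxyphenyl group with the non-aromatic six-membered carbon ring in this assay gave no change at the digits printed from compound 2 to compound 4 (within the scatter), and this agrees with the earlier result on the other core: the same change on two cores in this assay, a 1.4-fold higher number (0.15 log units; within the scatter) from compound 1 to compound 3 and no change at the digits printed (within the scatter) from compound 2 to compound 4, 1.4-fold (0.15 log units) apart, within the scatter of two such steps. In these two pairs, then, the change carried from the core of compound 1 to the core of compound 2 without moving the read-out beyond the usual scatter of repeated measurements. Going by these compounds alone, this is only two pairs, however, and their cores differ in more than one place, so it does not show that the same would hold on other cores, nor does it tell which of those differences, if any, matters for the change.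

The compounds shown leave open how other groups would read at this place on the five-membered ring, for example a plain phenyl or a 2,5-dimethoxyphenyl group. They also leave open what a longer chain in place of the acetyl group, or an amine in place of the chlorine of the 4-chlorophenyl group, would do to the concentration for total growth inhibition.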